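Amide tail variation in a cholesterol transporter binder series

The source may report more compounds than this note shows. Statements on the series, on what has been measured and on what is new or still open speak of the compounds shown alone.

Compound 3 `O=C(CN1CN(c2ccccc2)C2(CCN(C(=O)c3ccc(C4CCCCC4)cc3)CC2)C1=O)NCCO` stands second highest of the three numbers in an assay on HEK293 cells for displacement of a labelled ligand from NPC1-like intracellular cholesterol transporter 1 (Homo sapiens) (a lower number here means a stronger inhibitor, a higher number a weaker inhibitor), where compound 3 gives 2000 nM. Its nearest neighbour is compound 1 `CCC1CCCN(C(=O)CN2CN(c3ccccc3)C3(CCN(C(=O)c4ccc(C5CCCCC5)cc4)CC3)C2=O)C1`, which in this assay gives 2600 nM; the gap a 1.3-fold lower number from compound 1 to compound 3 (0.11 log units; within the scatter) lies within the scatter. The furthest is compound 2 `CC1(C)CC(OC(=O)CN2CN(c3ccccc3)C3(CCN(C(=O)c4ccc(C5CCCCC5)cc4)CC3)C2=O)CC(C)(C)N1`, which in this assay gives 600 nM; the gap a 3.3-fold higher number from compound 2 to compound 3 (0.52 log units; beyond the scatter) is beyond the scatter, as is a 4.3-fold lower number from compound 1 to compound 2 (0.64 log units; beyond the scatter).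

Compound 4 `COC(=O)CCNC(=O)CN1CN(c2ccccc2)C2(CCN(C(=O)c3ccc(C4CCCCC4)cc3)CC2)C1=O` differs from compound 3 by methoxycarbonyl in place of hydroxy on a saturated chain carbon, two bonds along the chain from an amide-type nitrogen. Among the compounds with values here, no measured step makes this particular exchange. The three steps that bear on it all rework the same amide substituent, and they span from no change beyond the scatter to a modest shift in either direction. On that basis the step in this assay is expected to be small, most likely within the scatter, with a modest move either way not excluded: no change at the digits printed from compound 3 to compound 4 (within the scatter). Compound 4 is therefore estimated at 2000 nM, within a range of 800 nM to 5000 nM.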

Compound 4, half-maximal inhibitory concentration: 12900 nM
Beside the measured number, compound 4's estimate is 6.5-fold (0.81 log units) below it, outside the stated range (above it).
By their numbers in this assay, from the lowest: compound 2; then compounds 3 and 1 (each within the scatter of the next); then compound 4.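

Within the amide tail, a change confined to the chain end, with the amide nitrogen kept, is enough to move the number in this assay beyond the scatter (a 6.5-fold higher number from compound 3 to compound 4 (0.81 log units; beyond the scatter)). Within the data shown here, the (2-(methoxycarbonyl)ethyl)amino tail also gives the weakest inhibitor of the four, both against the 3-ethylpiperidin-1-yl tail (a 5.0-fold higher number from compound 1 to compound 4 (0.70 log units; beyond the scatter)) and against the (2,2,6,6-tetramethylpiperidin-4-yl)oxy tail (a 22-fold higher number from compound 2 to compound 4 (1.33 log units; beyond the scatter)), the latter being the only large step in the set. Nothing shown here accounts for these steps.

Open, on these data alone, is whether the step follows from the loss of hydroxy or from the entry of methoxycarbonyl; a methoxy group, an amine or a carboxylic acid on the same chain carbon would help separate the two. Also open, as far as these compounds go, is how a longer chain carrying hydroxy would read.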